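Swapping an ester chain for a chlorophenyl group

A few compounds are considered here, and "the series" means these few. Any claim that something is new, unique, unknown or untested is made for them only; others in the source may bear on it.

Compound 2 `CCOC(=O)CCSc1nc2ccccc2n1CC(=O)O` gives 11400 nM in an assay on HEK293 cells for displacement of a labelled ligand from prostaglandin D2 receptor 2 (Homo sapiens) (a lower number here means a stronger inhibitor, a higher number a weaker inhibitor), the highest of the two numbers recorded so far. Its nearest neighbour is compound 1 `O=C(O)Cn1c(SCCc2ccccc2)nc2ccccc21`, which in this assay gives 881 nM. The two differ in one place, and the step was a 13-fold higher number from compound 1 to compound 2 (1.11 log units; beyond the scatter). Compound 3 `O=C(O)Cn1c(SCc2ccc(Cl)cc2)nc2ccccc21` has not yet been measured. It differs from compound 2 by 4-chlorophenyl in place of (ethoxycarbonyl)methyl on a saturated chain carbon bound to a sulfur. Going by the values given here, this change largely undoes the one that separates compound 1 from compound 2: an aromatic ring returns to the chain where the ester had been, although the ring now carries a chlorine and sits directly on the saturated chain carbon bound to the sulfur. Among the compounds with values here, the only measured step that bears on it is the one from compound 1 to compound 2, which was large, so a large step back downward is expected. For compound 3 the estimate in this assay is 900 nM, with a range from 250 nM to 3500 nM, meaning an expected step of a 13-fold lower number from compound 2 to compound 3 (1.10 log units; beyond the scatter).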

Compound 3, half-maximal inhibitory concentration: 160 nM
The estimate for compound 3 lay 5.6-fold (0.75 log units) above the measured number; the measured number lies below the stated range.
By their numbers in this assay, from the lowest: compound 3; then compound 1; then compound 2.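

In this assay, 4-chlorophenyl in place of (ethoxycarbonyl)methyl on a saturated chain carbon bound to a sulfur gives a 71-fold lower number from compound 2 to compound 3 (1.85 log units; beyond the scatter) and makes compound 3 the strongest inhibitor of the three. The aromatic group does more than recover the ground lost with the ester, since 4-chlorophenyl in place of benzyl at this same place gives a 5.5-fold lower number from compound 1 to compound 3 (0.74 log units; beyond the scatter), a modest step but one beyond the scatter. Nothing shown here explains these differences.

The step from benzyl to 4-chlorophenyl alters both the chlorine and the length of the chain at the sulfur, and the three compounds cannot separate those two changes. Going by these compounds, whether a plain phenyl at this place, or a bromine or methoxy group in place of the chlorine, would lower the number further remains open.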